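Triazole replacement on the benzyl aryl ring

The source may report more compounds than this note shows. Statements on the series, on what has been measured and on what is new or still open speak of the compounds shown alone.

Among the compounds with values here, compound 2 `Cc1cc(C)c(NC(=O)N(Cc2ccc(-c3ccn(C)n3)cc2)C2CCCCCC2)c(C)c1` is one of the two measured members. In a functional assay on a cell-free system (plasma) with sterol O-acyltransferase, Soat (Rattus norvegicus) as the target (a higher number here means that more compound is needed for the effect, a lower number that less compound is needed), compound 2 gives < 1 mg/kg, which is a limit of the assay and not a number. Compound 1 `Cc1cc(C)c(NC(=O)N(Cc2ccc(-n3cccn3)cc2)C2CCCCCC2)c(C)c1` differs from compound 2 only at the azole on the aromatic carbon. In this assay compound 1 gives > 1 mg/kg, again a limit. The step of a number no higher from compound 1 to compound 2 (the limit leaves the size open) is thus bounded on one side only, and its size cannot be read, since one value sits at the limit of < 1 mg/kg in this assay, at which 1 of the 2 values shown sits, and the other at the limit of > 1 mg/kg in this assay, at which 1 of the 2 values shown sits. Compound 3 `Cc1cc(C)c(NC(=O)N(Cc2ccc(-n3nccn3)cc2)C2CCCCCC2)c(C)c1` carries the change (2H-1,2,3-triazol-2-yl in place of 1-methyl-1H-pyrazol-3-yl on an aromatic carbon). Within the data shown here, the single measured step bears on it only loosely: it shows that exchanging one azole for another at this carbon can move the dose across the limit, but not by how much. Among the measured compounds shown here, no step in the set has a readable size, so no direction beyond the scatter is expected with confidence in this assay. The estimate for compound 3 is 1 mg/kg, within 0.3 mg/kg to 3 mg/kg. The expected step of a number no lower from compound 2 to compound 3 (the limit leaves the size open) is accordingly close to the limit, and the result may again be reported only as a limit.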

Compound 3, dose for half-maximal effect: > 1 mg/kg
Compound 3 gave a limit, no number; the forecaster's own chance of this, stated with the estimate: 60%; the middle value lies on the limit itself.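

In this assay compound 3 gives > 1 mg/kg, a limit of the assay and not a number. The exchange of azole gives a number no lower from compound 2 to compound 3 (the limit leaves the size open). The 2H-1,2,3-triazol-2-yl therefore falls on the same side of the limit as the 1H-pyrazol-1-yl of compound 1, and among the three azoles shown on this aromatic carbon, para to a large group, only the 1-methyl-1H-pyrazol-3-yl of compound 2 falls on the other side, so the position tolerates a change of azole without keeping the result on that side. No new step has a readable size, and compound 1 and compound 3 cannot be ordered against each other, because the values are limits: the limit of > 1 mg/kg in this assay, at which 2 of the 3 values shown sit.

The three compounds do not separate the methyl group from the change of azole itself, and a 1H-pyrazol-3-yl without the methyl group, or a 1-methyl-1H-1,2,3-triazol-4-yl, would bear directly on that question. As far as these compounds go, how far each compound lies from the limit also stays open, and a dose-response value in place of a limit for any of the three would be needed to give a step a size.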